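Dropping a Chain Methyl: Expected Effect on Cytotoxicity

The compounds below may be only part of what the source reports. "The series", "measured", "known", "first", "only" and "open" are said of these compounds alone.

The measure here is an ADME assay on cells (Homo sapiens) for cytotoxicity; a higher number here means that more compound is tolerated, a lower number that less compound is tolerated. Compound 1, `O=C1N(CCC(CCOc2ccc(-c3ccc(Cl)cc3)cc2)c2ccccc2)CCN1c1ccncc1`, gives > 25000 nM in this assay, a value that is a limit of the assay rather than a number. Compound 2, `CC(C)(CCOc1ccc(-c2ccc(Cl)cc2)cc1)CCN1CCN(c2ccncc2)C1=O`, gives > 25000 nM in this assay, which is likewise a limit and not a number. Compound 2 therefore stands at the limit of > 25000 nM in this assay, at which 2 of the 2 values shown sit, so no difference between the two can be read from these figures.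

Compound 3, `CC(CCOc1ccc(-c2ccc(Cl)cc2)cc1)CCN1CCN(c2ccncc2)C1=O`, differs from compound 2 by hydrogen in place of methyl on a saturated chain carbon bound to three saturated chain carbons. Among the compounds with values here, no measured step between compounds exists for this change, so there is no basis for expecting a shift beyond the usual scatter in either direction. Compound 3 is therefore expected to give about 30000 nM in this assay, with a range of 15000 nM to 60000 nM, and the expected step that the limit leaves unreadable from compound 2 to compound 3 is essentially none, most likely again reported only as a limit.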

Compound 3, half-maximal cytotoxic concentration: > 25000 nM
Compound 3 was reported as a limit; the forecaster's own chance of this, stated with the estimate: 85%; the middle value does not contradict the limit.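

Compound 3 also gives a limit rather than a number, so no step from compound 1 or compound 2 to compound 3 can be read: the limit of > 25000 nM in this assay, at which 3 of the 3 values shown sit.

Still open, from the compounds shown here alone, is whether hydrogen, methyl or phenyl on the chain makes any difference in this assay.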